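Methoxy on the benzylsulfanyl arm: compound 3 to compound 4

A few compounds are considered here, and "the series" means these few. Any claim that something is new, unique, unknown or untested is made for them only; others in the source may bear on it.

Measured so far:
compound 1 `Cc1cc(N2CC[C@@H](C)[C@@H](N(C)c3ncnc4[nH]ccc34)C2)n2ncnc2n1`, 4350 nM
compound 2 `CCCSc1nc2nc(C)cc(N3CC[C@@H](C)[C@@H](N(C)c4ncnc5[nH]ccc45)C3)n2n1`, 15500 nM
compound 3 `Cc1cc(N2CC[C@@H](C)[C@@H](N(C)c3ncnc4[nH]ccc34)C2)n2nc(SCc3ccccc3)nc2n1`, 5870 nM

All three share one core and were read in a functional assay on MGC-803 cells (Homo sapiens) for inhibition, read by MTT assay, with a stated time of 72 h; on this read-out higher numbers stand for weaker inhibition and lower numbers for stronger inhibition. Compound 3 stands second highest of the three numbers; its neighbour is compound 1, and the gap a 1.3-fold higher number from compound 1 to compound 3 (0.13 log units; within the scatter) lies within the scatter. Compound 2 is the furthest away, with a 2.6-fold lower number from compound 2 to compound 3 (0.42 log units; beyond the scatter).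

Compound 4 `COc1ccc(CSc2nc3nc(C)cc(N4CC[C@@H](C)[C@@H](N(C)c5ncnc6[nH]ccc56)C4)n3n2)cc1` differs from compound 3 in one place: methoxy in place of hydrogen on an aromatic carbon. For the measured compounds named here, no measured step alters a group of this kind, so the expectation rests on the two steps that touch the same arm. Adding the whole benzylsulfanyl group left the number unchanged within the scatter, and exchanging ethyl for phenyl on the chain carbon bound to sulfur moved it only modestly. A small addition on the outer ring of that arm is therefore expected to produce a step of about a 1.1-fold lower number from compound 3 to compound 4 (0.03 log units; within the scatter), that is, nothing beyond the scatter. The estimate for compound 4 in this assay is 5500 nM, with a range from 2500 nM to 12000 nM.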

Compound 4, half-maximal inhibitory concentration: 15200 nM
Beside the measured number, compound 4's estimate is 2.8-fold (0.44 log units) below it, and the stated range ends below it.
By their numbers in this assay, from the lowest: compounds 1 and 3 (each within the scatter of the next); then compounds 4 and 2 (each within the scatter of the next).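

In this assay the outer ring of the benzylsulfanyl arm responds to substitution: methoxy para to a large group gives a 2.6-fold higher number from compound 3 to compound 4 (0.41 log units; beyond the scatter) as a step beyond the scatter. Tolerance of the benzylsulfanyl arm therefore does not carry over to (4-methoxybenzyl)sulfanyl, which gives a 3.5-fold higher number from compound 1 to compound 4 (0.54 log units; beyond the scatter) against the hydrogen of the unsubstituted position, whereas benzylsulfanyl stayed within the scatter of that hydrogen. The exchange of ethyl for 4-methoxyphenyl gives a 1.0-fold lower number from compound 2 to compound 4 (0.01 log units; within the scatter) within the scatter, so this arm, unlike benzylsulfanyl, is not separated from propylsulfanyl.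

On these data alone, whether the shift belongs to methoxy or to any group at this place stays open, and a fluorine, a hydroxyl or an amine on the same ring would bear on that. Nothing available accounts for the shift.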